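The source may report more compounds than this note shows. Statements on the series, on what has been measured and on what is new or still open speak of the compounds shown alone.

Measured compounds:
compound 1 `CCCCCOC(=O)C(C)ON1C(=O)c2ccccc2C1=O` — 64%
compound 2 `CCCCOC(=O)C(C)ON1C(=O)c2ccccc2C1=O` — 59%
compound 3 `CCOC(=O)C(C)(C)ON1C(=O)c2ccccc2C1=O` — 0%

Compound 4 `CCOC(=O)C(C)ON1C(=O)c2ccccc2C1=O` is not yet measured. The read-out throughout is a functional assay on the whole organism for inhibition, with Lepidium sativum as the target, tested at 1 ppm; on this read-out higher numbers stand for more inhibition of growth at the one concentration tested and lower numbers for less inhibition of growth.

Among the measured compounds shown here, the one counted step among measured compounds is hydrogen in place of methyl on a saturated chain carbon, four bonds along the chain from an oxygen next to a carbonyl group, which gave a number 5 percentage points lower from compound 1 to compound 2 (within the scatter). Compound 3 stands apart from both; the difference between its core and that of compound 1 is not broken down here. In this assay compound 3 gives 0%, the lowest of the three numbers and beyond the scatter from either of the others.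

Compound 4 arises from compound 3 by hydrogen in place of methyl on a saturated chain carbon bound to a carbonyl carbon, an oxygen on an unsaturated carbon and a saturated chain carbon. This is the same kind of change as from compound 1 to compound 2, but not the same: there the place was four bonds along the chain from an oxygen next to a carbonyl group, here it is the carbon bound to a carbonyl carbon, an oxygen on an unsaturated carbon and a saturated chain carbon. Compounds 1 and 2 carry hydrogen at this last place and give the higher numbers; compound 3 carries methyl there and gives 0%. On that the expected step of a number 50 percentage points higher from compound 3 to compound 4 (beyond the scatter) rests, larger than the earlier one. For compound 4 the estimate is 50%, expected between 20% and 70%.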

Compound 4, percent growth inhibition at one concentration: 68%
Estimate against measurement, compound 4: 18 percentage points below; the range from low to high includes it.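

In this assay, hydrogen in place of methyl does not carry over from one core to another as a single step of fixed size: the same change on two cores in this assay, a number 5 percentage points lower (within the scatter) from compound 1 to compound 2 and a number 68 percentage points higher (beyond the scatter) from compound 3 to compound 4, 73 percentage points apart, beyond the scatter of two such steps

The two steps also sit at different places: the large one, a number 68 percentage points higher from compound 3 to compound 4 (beyond the scatter), is on a saturated chain carbon bound to a carbonyl carbon, an oxygen on an unsaturated carbon and a saturated chain carbon, while the earlier one is four bonds along the chain from an oxygen next to a carbonyl group. The outer chain shows no step beyond the scatter, with hydrogen in place of ethyl giving a number 9 percentage points higher from compound 2 to compound 4 (within the scatter) and hydrogen in place of propyl giving a number 4 percentage points higher from compound 1 to compound 4 (within the scatter), but these compounds do not show why methyl at the inner place goes with the low number.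

Methyl at the inner place appears only on compound 3, so its effect on the cores of compound 1 and compound 2 remains open. Also open, on these data alone, is how a longer chain at that place, or a carboxylic acid in place of the chain-bearing carbonyl oxygen, would read.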